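A few compounds are considered here, and "the series" means these few. Any claim that something is new, unique, unknown or untested is made for them only; others in the source may bear on it.

Measured compounds:
- compound 1 `Cc1cccc(N2CCN(C(=O)CN3C(=O)CC(C)(c4ccccc4)C3=O)CC2)c1`: 100 mg/kg
- compound 2 `COc1cccc(N2CCN(C(=O)CN3C(=O)CC(C)(c4ccccc4)C3=O)CC2)c1`: "not active" (no number reported)

In a functional assay on the whole organism (strain CD-1) with Mus musculus as the target, in the maximal electroshock model, with a stated time of 0.5 h (on this read-out higher numbers stand for an effect only at larger amounts of compound and lower numbers for an effect already at smaller amounts), compound 1 gives 100 mg/kg. In this assay, for the measured compounds named here, compound 2 gives "not active" (no number reported), so compound 2 stands without a single number, and no step between it and compound 1 can be sized.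

Compound 3 `CC1(c2ccccc2)CC(=O)N(CC(=O)N2CCN(c3ccccc3Cl)CC2)C1=O` is not yet measured. It differs from compound 2 by 2-chlorophenyl in place of 3-methoxyphenyl on an amine nitrogen in a ring. Going by the values given here, since compound 2 has no number, no step from compound 2 to compound 3 can be computed; the only anchor is compound 1 with its 100 mg/kg, which shares the same core and differs from compound 3 only in the group on the ring nitrogen.

Compound 3 is therefore expected to come out near compound 1, estimated at 100 mg/kg, with a range from 30 mg/kg to 300 mg/kg, and with a real chance that, like compound 2, it is reported without a number.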

Compound 3, minimum effective dose: "not active" (no number reported)
No number was reported for compound 3, so the estimate cannot be set against anything.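

In this assay, for the compounds shown here, compound 3 gives "not active" (no number reported), and compound 2 likewise has no number, so no step involving compound 3 can be read. The compounds shown leave open whether 2-chlorophenyl in place of 3-methoxyphenyl changes the minimum effective dose at all. No evidence bears on this result.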